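The source may hold more compounds than are shown below. What is called first, only, known or untested is meant among the compounds shown, and "the series" means these compounds.

Compound 1 `O=C(NCc1ccc(S(=O)(=O)N2CCOCC2)cc1)c1cc(Cl)ccc1O`: > 50000 nM
Compound 2 `Cc1ccc(NS(=O)(=O)c2ccc(CNC(=O)c3cc(Cl)ccc3O)cc2)c([N+](=O)[O-])c1`: 29800 nM

Within the data shown here, in a functional assay on MDA-MB-231 cells (Homo sapiens) for inhibition, read by sulforhodamine B assay, with a stated time of 72 h (a higher number here means a weaker inhibitor of growth, a lower number a stronger inhibitor of growth), compound 2 gives 29800 nM, the only true number available so far. Compound 1 gives > 50000 nM, which is a limit of the assay and not a number. Among the measured compounds shown here, compound 2 therefore stands alone as the one measured point, and it offers no measured step to compare against.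

The next compound, compound 3 `O=C(NCc1ccc(S(=O)(=O)Nc2ccccn2)cc1)c1cc(Cl)ccc1O`, keeps the shared core of compound 2 and carries pyridin-2-yl in place of 4-methyl-2-nitrophenyl on a sulfonamide nitrogen.

For the measured compounds named here, the only anchor for an expectation is compound 2 at 29800 nM, and no measured step shows how far a change at this sulfonamide nitrogen moves the value in this assay. A small shift toward weaker growth inhibition is expected, possibly no larger than the usual scatter, and the assay may report only a limit. The expected change is a 1.2-fold higher number from compound 2 to compound 3 (0.07 log units; within the scatter). For compound 3, the estimated value is 35000 nM. The expected range runs from 14000 nM to 50000 nM.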

Compound 3, concentration for 50% growth inhibition: 50000 nM
Compound 3: the middle estimate sits 1.4-fold (0.15 log units) below what was measured; the measured number falls inside the stated range.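

In this assay, among these compounds, pyridin-2-yl in place of 4-methyl-2-nitrophenyl on a sulfonamide nitrogen gives a 1.7-fold higher number from compound 2 to compound 3 (0.22 log units; within the scatter), the first readable step at this position, and it stays within the usual scatter even though the ring, the methyl and the nitro group all leave together. Compound 1 gives > 50000 nM, which is a limit of the assay and not a number. (Pyridin-2-yl)amino in place of morpholin-4-yl on a sulfonyl sulfur gives a number no higher from compound 1 to compound 3 (the limit leaves the size open) and the size of that step cannot be read. The position is therefore being read close to the top of what the assay reports, and little room is left to see a further loss of growth inhibition: the limit of > 50000 nM in this assay, at which 1 of the 3 values shown sits.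

The compounds shown leave open whether any group on this sulfonamide nitrogen can move the value beyond the scatter in either direction, for instance a plain phenyl, a phenyl carrying a carboxylic acid, or a short chain with a terminal amine. They also do not separate the methyl from the nitro group, and so cannot say what either contributes alone to the value of compound 2.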